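Extending the chain on a hydroxycarbamoyl-bearing pyrrolopyridine core

The source may report more compounds than this note shows. Statements on the series, on what has been measured and on what is new or still open speak of the compounds shown alone.

Measured so far:
compound 1 `Nc1ncnc2c1c(-c1cnc3[nH]ccc3c1)nn2CCCC(=O)NO` gives > 150000 nM
compound 2 `Nc1nc2cc(-c3nn(CCCCCC(=O)NO)c4ncnc(N)c34)ccc2o1` gives 21500 nM

Going by the values given here, compound 1 is measured in a functional assay on HCT-116 cells (Homo sapiens) for inhibition, read by MTT assay, with a stated time of 72 h (a lower number here means a stronger inhibitor, a higher number a weaker inhibitor), where it reaches only the limit > 150000 nM; that value is a limit of the assay, not a number, and it is the sole fixed point for compound 1 (the limit of > 150000 nM in this assay, at which 1 of the 2 values shown sits). Compound 2, which carries a different aryl group and a 5-(hydroxycarbamoyl)pentyl chain, gives 21500 nM in this assay. Among the compounds with values here, no pair of measured compounds differs in one place, so no measured step exists.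

Compound 3 `Nc1ncnc2c1c(-c1cnc3[nH]ccc3c1)nn2CCCCCC(=O)NO` has not been measured. It differs from compound 1 as follows: 2-(hydroxycarbamoyl)ethyl in place of hydroxycarbamoyl on a saturated chain carbon, three bonds along the chain from an aromatic nitrogen This converts the 3-(hydroxycarbamoyl)propyl chain of compound 1 into the 5-(hydroxycarbamoyl)pentyl chain found in compound 2. For compound 3 a gain in this assay beyond the scatter is expected, an at least 5.0-fold lower number from compound 1 to compound 3 (0.69 log units; beyond the scatter), because compound 2 gives 21500 nM with that same chain. Compound 3 is therefore estimated at 30000 nM, within 8000 nM to 150000 nM.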

Compound 3, half-maximal inhibitory concentration: 63700 nM
Estimate against measurement, compound 3: 2.1-fold (0.33 log units) below; the measured number falls inside the stated range.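

On the shared core, replacing the 3-(hydroxycarbamoyl)propyl chain with the 5-(hydroxycarbamoyl)pentyl chain gives the first step read at this position in this assay: an at least 2.3-fold lower number from compound 1 to compound 3 (0.37 log units; beyond the scatter). Chain length at this position therefore changes the read-out on this core, and compound 3 gives a number, 63700 nM, where the shorter chain gave none. The true size of the step remains unknown, and only its lower bound can be read, as compound 1 stands at a limit of the assay and not at a number: the limit of > 150000 nM in this assay, at which 1 of the 3 values shown sits.

On these data alone, it remains open whether a longer chain than the 5-(hydroxycarbamoyl)pentyl chain would lower the number further or whether the trend stops at this length. Also open, as far as these compounds go, is how a carboxylic acid or a primary amide in place of the hydroxycarbamoyl end would read on this same chain.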